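The source may report more compounds than this note shows. Statements on the series, on what has been measured and on what is new or still open speak of the compounds shown alone.

Measured so far:

Compound 1 `Cc1cc(NC(=O)Nc2ccc(F)cc2)c2ccccc2n1` gives > 25000 nM, a limit of the assay and not a number.
Compound 2 `Cc1cc(NC(=O)Nc2ccc(F)c(F)c2)c2ccccc2n1` gives > 25000 nM, likewise a limit.
Compound 3 `Cc1cc(NC(=O)Nc2cccnc2)c2ccccc2n1` gives > 25000 nM, again a limit.

In an ADME assay on HEK293 cells (Homo sapiens) for cytotoxicity, with a stated time of 72 h (a higher number here means that more compound is needed for the effect, a lower number that less compound is needed), compound 1 thus stands only at a limit, with no exact number known. The same holds for every value shown, as all three sit at the limit of > 25000 nM in this assay, at which 3 of the 3 values shown sit. The change examined here is carbamoyl in place of fluoro on an aromatic carbon, which turns compound 1 into compound 4 `Cc1cc(NC(=O)Nc2ccc(C(N)=O)cc2)c2ccccc2n1`. Two measured steps start from compound 1: a step that the two limits leave unreadable from compound 1 to compound 2 and a step that the two limits leave unreadable from compound 1 to compound 3. Neither can be read as a size, because both ends sit at the limit of > 25000 nM in this assay, at which 3 of the 3 values shown sit, so they give no direction for this assay. Compound 4 is therefore expected to give 25000 nM, within 10000 nM to 80000 nM. The step of a number no higher from compound 1 to compound 4 (the limit leaves the size open) is expected to stay within the scatter.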

Compound 4, half-maximal effective concentration: > 25000 nM
Compound 4 was reported as a limit; the forecaster's own chance of this, stated with the estimate: 85%; the middle value lies on the limit itself.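

Compound 4, like compound 1, stands only at a limit and not at a number, so the step between them cannot be read as a size: the limit of > 25000 nM in this assay, at which 4 of the 4 values shown sit.

The compounds shown leave open whether any of these changes alters the concentration needed for the effect in this assay.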